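A few compounds are considered here, and "the series" means these few. Any claim that something is new, unique, unknown or untested is made for them only; others in the source may bear on it.

Measured compounds:
- compound 1, `O=c1cc[nH]c(=O)n1C1CN(S(=O)(=O)c2ccccc2[N+](=O)[O-])c2ccccc2CO1`, 50900 nM
- compound 2, `O=c1ccn(C2CN(S(=O)(=O)c3ccccc3[N+](=O)[O-])c3ccccc3CO2)c(=O)[nH]1`, 45200 nM
- compound 3, `O=[N+]([O-])c1ccccc1S(=O)(=O)N1CC(n2cnc3ncnc(O)c32)OCc2ccccc21`, 19700 nM

All three were tested in a functional assay on MCF7 cells (Homo sapiens) for antiproliferative activity; a higher number here means a weaker inhibitor, a lower number a stronger inhibitor. Compound 2 stands second highest of the three numbers: its nearest neighbour is compound 1, with a 1.1-fold lower number from compound 1 to compound 2 (0.05 log units; within the scatter), while compound 3 lies furthest away, with a 2.3-fold lower number from compound 2 to compound 3 (0.36 log units; beyond the scatter).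

Compound 4, `O=c1ccn(C2CN(S(=O)(=O)c3ccc([N+](=O)[O-])cc3)c3ccccc3CO2)c(=O)[nH]1`, has the same atoms as compound 2, joined differently: 4-nitrophenyl in place of 2-nitrophenyl on a sulfonyl sulfur.

Among the compounds with values here, none of the measured steps touches this part of the molecule. The steps from compound 1 to compound 2, from compound 1 to compound 3 and from compound 2 to compound 3 all exchange the group on the saturated ring carbon, and two of them are beyond the scatter, so that position clearly matters. The nitrophenyl on the sulfonyl sulfur is identical in all three measured compounds, so nothing here shows what moving the nitro group does. The expectation for compound 4 is therefore no step beyond the scatter in this assay, a step of a 1.0-fold lower number from compound 2 to compound 4 (0.00 log units; within the scatter), with a wide range on either side. Compound 4 is expected to give about 45000 nM, between 15000 nM and 135000 nM.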

Compound 4, half-maximal inhibitory concentration: 39800 nM
For compound 4 the middle estimate is 1.1-fold (0.05 log units) above the measured one; measured number inside the range.
By their numbers in this assay, from the lowest: compound 3; then compounds 4, 2 and 1 (each within the scatter of the next).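

The swap of 2-nitrophenyl for 4-nitrophenyl on the sulfonyl sulfur gives, in this assay, a 1.1-fold lower number from compound 2 to compound 4 (0.06 log units; within the scatter), so the two placements of the nitro group cannot be told apart here. Within the data shown here, this is the first measured change at this part of the molecule, as the earlier steps all exchanged the group on the saturated ring carbon. Nothing available explains why the two compounds read alike.

Still open, going by these compounds, is whether the nitro group matters at all on this ring, which a plain phenyl, or an amine or a carboxylic acid in place of the nitro group, could test. Also open, on these data alone, is whether 4-nitrophenyl reads the same when combined with the group that compound 3 carries on the saturated ring carbon.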